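Swapping a phenyl for a furan ring on two amide chains

The compounds below may be only part of what the source reports. "The series", "measured", "known", "first", "only" and "open" are said of these compounds alone.

Three related amides have been tested in a functional assay on MCF7 cells (Homo sapiens) for cytotoxicity, read by MTT assay, with a stated time of 48 h; a higher number here means a weaker inhibitor, a lower number a stronger inhibitor. Compound 1 `CCCCCCCCCCCCNC(=O)[C@@H](NC(=O)c1ccccc1)[C@@H](C)O` gives 36600 nM. Compound 2 `CCCCCCCCCCCCNC(=O)[C@@H](NC(=O)c1ccco1)[C@@H](C)O` gives 67500 nM. Compound 3 `CCCCCCCCCCCCCCCCCCNC(=O)[C@@H](NC(=O)c1ccccc1)[C@@H](C)O` gives 31800 nM.

Compound 2 differs from compound 1 by a single change: furan-2-yl in place of phenyl on a carbonyl carbon. The step was a 1.8-fold higher number from compound 1 to compound 2 (0.27 log units; within the scatter). Compound 3 differs from compound 1 at the far end of the chain, and the step was a 1.2-fold lower number from compound 1 to compound 3 (0.06 log units; within the scatter). Compound 3 carries the lowest number of the three, but its gap to compound 1 lies within the scatter, so those two cannot be ranked; only its gap to compound 2 lies beyond it.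

Compound 4 `CCCCCCCCCCCCCCCCCCNC(=O)[C@@H](NC(=O)c1ccco1)[C@@H](C)O` has not yet been measured. It stands to compound 3 as compound 2 stands to compound 1, the same change at the same place: furan-2-yl in place of phenyl on a carbonyl carbon. The two cores differ by hexyl in place of hydrogen on a saturated chain carbon, ten or more bonds along the chain from an amide-type nitrogen.

Because the same change made a 1.8-fold higher number from compound 1 to compound 2 (0.27 log units; within the scatter) on the shorter chain, compound 4 is expected to show a 1.8-fold higher number from compound 3 to compound 4 (0.25 log units; within the scatter). Compound 4 is estimated at 57000 nM in this assay, most likely between 25000 nM and 130000 nM.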

Compound 4, half-maximal inhibitory concentration: 21400 nM
Estimate against measurement, compound 4: 2.7-fold (0.43 log units) above, and the stated range ends above it.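

In this assay, furan-2-yl in place of phenyl on the longer chain gave a 1.5-fold lower number from compound 3 to compound 4 (0.17 log units; within the scatter), while hexyl in place of hydrogen on the furan core gave a 3.2-fold lower number from compound 2 to compound 4 (0.50 log units; beyond the scatter). The furan step therefore does not carry over unchanged from the shorter chain to the longer one, yet neither step alone lies beyond the scatter, so a true reversal of direction is not shown: the same change on two cores in this assay, a 1.8-fold higher number (0.27 log units; within the scatter) from compound 1 to compound 2 and a 1.5-fold lower number (0.17 log units; within the scatter) from compound 3 to compound 4, 2.7-fold (0.44 log units) apart, beyond the scatter of two such steps The hexyl step likewise differs between the phenyl and furan cores, which shows that the two changes do not simply add up in these four compounds but does not show why: the same change on two cores in this assay, a 1.2-fold lower number (0.06 log units; within the scatter) from compound 1 to compound 3 and a 3.2-fold lower number (0.50 log units; beyond the scatter) from compound 2 to compound 4, 2.7-fold (0.44 log units) apart, beyond the scatter of two such steps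

As far as these compounds go, it remains open whether a different ring on the carbonyl carbon, such as thiophene or pyridine, would follow compound 2 or compound 4. From the compounds shown here alone, it is also open how a longer chain than that of compound 4 would behave with either the phenyl or the furan-2-yl group.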